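A few compounds are considered here, and "the series" means these few. Any claim that something is new, unique, unknown or untested is made for them only; others in the source may bear on it.

The three measured compounds share one core and differ only in the chain on the aromatic nitrogen. Compound 1 `CCCn1c(SCc2cc([N+](=O)[O-])ccc2OC)nc2cc(NC(=O)NC(C)(C)C)ccc21` gives 120 nM in an assay on isolated protein for inhibition of Gonadotropin-releasing hormone receptor (Rattus norvegicus); on this read-out lower numbers stand for stronger inhibition and higher numbers for weaker inhibition. Compound 2 `CCCCn1c(SCc2cc([N+](=O)[O-])ccc2OC)nc2cc(NC(=O)NC(C)(C)C)ccc21` gives 330 nM in this assay, and compound 3 `COCCn1c(SCc2cc([N+](=O)[O-])ccc2OC)nc2cc(NC(=O)NC(C)(C)C)ccc21` gives 280 nM. Among these three numbers compound 3 stands second highest; its value and that of compound 2 lie within the scatter of each other, while compound 1 sits at a lower number, beyond the scatter. The step of a 2.8-fold higher number from compound 1 to compound 2 (0.44 log units; beyond the scatter) was modest, the step of a 2.3-fold higher number from compound 1 to compound 3 (0.37 log units; beyond the scatter) was of similar size, and the step of a 1.2-fold lower number from compound 2 to compound 3 (0.07 log units; within the scatter) stayed within the scatter.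

Compound 4 `COc1ccc([N+](=O)[O-])cc1CSc1nc2cc(NC(=O)NC(C)(C)C)ccc2n1Cc1ccccc1` is not yet measured. It differs from compound 3 by phenyl in place of methoxymethyl on a saturated chain carbon bound to an aromatic nitrogen. All three measured steps concern this same chain on the aromatic nitrogen, so they bear on the change, yet none of them introduces a ring: the two departures from compound 1 each raised the number modestly, and swapping ethyl for methoxy left the number unchanged within the scatter. Within the data shown here, nothing among the measured compounds shows what an aromatic ring at this place does. The account therefore expects for compound 4 a step of a 1.1-fold higher number from compound 3 to compound 4 (0.03 log units; within the scatter) that stays within the scatter, and estimates 300 nM, with a range from 100 nM to 900 nM.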

Compound 4, half-maximal inhibitory concentration: 160 nM
Beside the measured number, compound 4's estimate is 1.9-fold (0.27 log units) above it, within the range that was stated.
By their numbers in this assay, from the lowest: compounds 1, 4, 3 and 2 (each within the scatter of the next, the first and the last beyond it).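

In this assay compound 4 brings the first ring to this place, and the benzyl chain gives a number that cannot be told apart from those of the smaller chains: a 1.3-fold higher number from compound 1 to compound 4 (0.12 log units; within the scatter) and a 1.8-fold lower number from compound 3 to compound 4 (0.24 log units; within the scatter) both stay within the scatter. Only a 2.1-fold lower number from compound 2 to compound 4 (0.31 log units; beyond the scatter) goes beyond the scatter, and that step is modest, so an aromatic ring on the saturated chain carbon bound to the aromatic nitrogen is accepted here without a clear loss against compound 1 or compound 3. The number therefore does not simply follow the heavy-atom count of this chain, with compound 2 the one that stands apart from compound 1 and compound 4, and nothing given here accounts for this result.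

The compounds shown leave open whether a ring at this place tolerates added groups, such as a methoxy or a chlorine on the phenyl, or a ring nitrogen as in pyridylmethyl. They also leave open what a longer link to the ring, as in 2-phenylethyl, or a terminal amine or carboxylic acid on the chain would do.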